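The source may hold more compounds than are shown below. What is called first, only, known or untested is meant among the compounds shown, and "the series" means these compounds.

Compound 1 `N#Cc1ccc(Nc2nc(Oc3ccnc4ccccc34)nc(N3CCCCC3)n2)cc1C(F)(F)F`: in a functional assay on DU-145 cells (Homo sapiens) for cytotoxicity, read by sulforhodamine B assay, with a stated time of 48 h (a higher number here means a weaker inhibitor of growth, a lower number a stronger inhibitor of growth), compound 1 gives > 100000 nM, which is a limit of the assay and not a number.
Compound 2 `N#Cc1ccc(Nc2nc(Oc3ccnc4ccccc34)nc(N3CCN(c4ccccc4F)CC3)n2)cc1C(F)(F)F`: in this assay compound 2 gives > 100000 nM, again a limit.
Compound 3 `N#Cc1ccc(Nc2nc(Oc3ccnc4ccccc34)nc(N3CCN(c4ccccn4)CC3)n2)cc1C(F)(F)F`: in this assay compound 3 gives > 100000 nM, also a limit.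

Compound 3 therefore stands only at a limit, and the two further values shown are limits as well, which is the limit of > 100000 nM in this assay, at which 3 of the 3 values shown sit. Compound 4 `CC1CC(C)CN(c2nc(Nc3ccc(C#N)c(C(F)(F)F)c3)nc(Oc3ccnc4ccccc34)n2)C1` differs from compound 3 in one place: 3,5-dimethylpiperidin-1-yl in place of 4-(pyridin-2-yl)piperazin-1-yl on an aromatic carbon. The measured steps that bear on this change, a step that the two limits leave unreadable from compound 1 to compound 3 and a step that the two limits leave unreadable from compound 2 to compound 3, both run between limits, so their size and direction cannot be read. Because the limit of > 100000 nM in this assay, at which 3 of the 3 values shown sit, holds for every value shown, compound 4 is expected to stay at the limit, a step of a number no higher from compound 3 to compound 4 (the limit leaves the size open). Compound 4 is thus estimated at 100000 nM, with a range from 50000 nM to 200000 nM.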

Compound 4, concentration for total growth inhibition: 68000 nM
The estimate for compound 4 lay 1.5-fold (0.17 log units) above the measured number; measured number inside the range.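

At this position on the shared core, 3,5-dimethylpiperidin-1-yl gives the only readable number among the compounds shown in this assay. Replacing 4-(pyridin-2-yl)piperazin-1-yl gives an at least 1.4-fold lower number from compound 3 to compound 4 (0.16 log units; that floor lies within the scatter), and replacing piperidin-1-yl gives an at least 1.4-fold lower number from compound 1 to compound 4 (0.16 log units; that floor lies within the scatter). Most values still sit at the limit: the limit of > 100000 nM in this assay, at which 3 of the 4 values shown sit.

The steps among compound 1, compound 2 and compound 3 run between limits and cannot be read. On these data alone, the true size of the two new steps also stays open, as does whether an amine or a longer alkyl chain at this position would give a lower number.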